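A Methoxy Swap in a Flat Series

A few compounds are considered here, and "the series" means these few. Any claim that something is new, unique, unknown or untested is made for them only; others in the source may bear on it.

For the measured compounds named here, in a functional assay on KB cells (Homo sapiens) for inhibition, read by sulforhodamine B assay (a higher number here means a weaker inhibitor of growth, a lower number a stronger inhibitor of growth), three compounds sharing one core have numbers so far: compound 1 `Oc1cccc2[nH]c(-c3ccc(-c4ccc(-c5ccccc5)cc4)cc3)nc12` (4010 nM), compound 2 `Oc1cccc2[nH]c(-c3ccc(-c4ccc(-c5ccc(F)cc5)cc4)cc3)nc12` (6920 nM) and compound 3 `Oc1cccc2[nH]c(-c3ccc(-c4ccc(-c5ccc(C(F)(F)F)cc5)cc4)cc3)nc12` (4320 nM). Compound 3 lies within the usual scatter of both others, so these numbers set no order among the three.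

Compound 4 `COc1ccc(-c2ccc(-c3ccc(-c4nc5c(O)cccc5[nH]4)cc3)cc2)cc1` has not been measured yet. It differs from compound 3 as follows (methoxy in place of trifluoromethyl on an aromatic carbon): methoxy in place of trifluoromethyl on an aromatic carbon.

Going by the values given here, three measured steps bear on this change. Fluoro in place of hydrogen gave (a 1.7-fold higher number from compound 1 to compound 2 (0.24 log units; within the scatter)), and trifluoromethyl in place of fluoro gave (a 1.6-fold lower number from compound 2 to compound 3 (0.20 log units; within the scatter)). Trifluoromethyl in place of hydrogen gave (a 1.1-fold higher number from compound 1 to compound 3 (0.03 log units; within the scatter)). All three lie within the scatter. None of them involves methoxy, so they are only an indirect guide.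

With steps this small, no step beyond the scatter is expected here, and the estimated step is small (a 1.0-fold higher number from compound 3 to compound 4 (0.02 log units; within the scatter)). For compound 4 the expected value is about 4500 nM with an estimated range from (1800 nM) to (10000 nM).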

Compound 4, concentration for 50% growth inhibition: 4900 nM
Compound 4: the middle estimate sits 1.1-fold (0.04 log units) below what was measured; measured number inside the range.
By their numbers in this assay, from the lowest: compounds 1, 3, 4 and 2 (each within the scatter of the next).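

In this assay, methoxy brings an oxygen and one hydrogen-bond acceptor to this aromatic carbon, para to a large group, where trifluoromethyl has none, yet the swap stays within the scatter (a 1.1-fold higher number from compound 3 to compound 4 (0.05 log units; within the scatter)). The comparisons with the other two compounds read the same way (a 1.4-fold lower number from compound 2 to compound 4 (0.15 log units; within the scatter); a 1.2-fold higher number from compound 1 to compound 4 (0.09 log units; within the scatter)), so hydrogen, fluoro, trifluoromethyl and methoxy at this position cannot be told apart by these numbers, and a fourth group, the first here to bring in oxygen, extends the flat picture that the earlier three compounds gave. No measurement available here offers an explanation for this flat picture.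

On these data alone, what a quite different group at this position would do remains open, for example an amine, a carboxylic acid or a longer chain, any of which might or might not produce a step beyond the scatter. For the compounds shown here, also open is whether changes elsewhere on the shared core would matter more for growth inhibition than anything tried at this position so far.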